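This account rests on a few compounds, and the source may have more. Where it says the series, first, only, none or still open, it means among the compounds named here.

Compound 2 `COc1cc(Oc2c(C)cc(C)cc2C)cc(Nc2ccc(C#N)cc2)n1` and compound 1 `COc1cc(Oc2c(C)cc(C#N)cc2C)cc(Nc2ccc(C#N)cc2)n1` share one core and differ by cyano in place of methyl on an aromatic carbon. In an ADME assay on MT4 cells (Homo sapiens) for cytotoxicity, read by MTT assay, with a stated time of 5 days (a lower number here means that less compound is tolerated, a higher number that more compound is tolerated), compound 2 gives 29000 nM. For compound 1 this assay reports only a limit, > 147000 nM. Together these give an at least 5.0-fold higher number from compound 2 to compound 1 (0.70 log units; beyond the scatter), a step resting on (the limit of > 147000 nM in this assay, at which 1 of the 3 values shown sits). Compound 3 `Cc1cc(C)c(Oc2cc(Nc3ccc(C#N)cc3)[nH]c(=O)c2Br)c(C)c1` carries a different core; the difference between the two cores is not broken down here. In this assay compound 3 also reaches only a limit, > 294000 nM, which is the limit of > 294000 nM in this assay, at which 1 of the 3 values shown sits. Compound 4 `Cc1cc(C#N)cc(C)c1Oc1cc(Nc2ccc(C#N)cc2)[nH]c(=O)c1Br` is not yet measured and differs from compound 3 by cyano in place of methyl on an aromatic carbon, the same change in the same surroundings. Given an at least 5.0-fold higher number from compound 2 to compound 1 (0.70 log units; beyond the scatter), compound 4 is expected to stay at that limit, meaning a step that the limit leaves unreadable from compound 3 to compound 4. The estimate for compound 4 is 320000 nM, between 150000 nM and 700000 nM.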

Compound 4, half-maximal cytotoxic concentration: > 287000 nM
Compound 4 was reported as a limit (the forecaster's own chance of this, stated with the estimate: 85%); the middle value does not contradict the limit.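

Compound 3 and compound 4 both reach only a limit in this assay, so the step between them cannot be read. The compounds shown leave open whether cyano in place of methyl changes tolerance on this core.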